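A few compounds are considered here, and "the series" means these few. Any claim that something is new, unique, unknown or untested is made for them only; others in the source may bear on it.

In a functional assay on PC-3 cells (Homo sapiens) for antiproliferative activity, read by MTT assay, with a stated time of 72 h (a higher number here means a weaker inhibitor, a lower number a stronger inhibitor), compound 3 (`CCCCCCCCCCCCCCNC[C@@H]1OC[C@H](N)[C@H]1O`) gives 1990 nM, the lowest of the three numbers measured and beyond the scatter from both others. Compound 1 (`CCCCCCCCCCNC[C@@H]1OC[C@H](N)[C@@H]1O`) gives 11900 nM and compound 2 (`CCCCCCCNC[C@@H]1OC[C@H](N)[C@@H]1O`) gives 22400 nM. Compound 4 (`CCCCCCCCCCCCCCNC[C@@H]1OC[C@H](N)[C@@H]1O`) has not yet been measured. It departs from compound 3 in one respect: the two compounds have the same atoms and bonds and differ only in configuration as drawn: 1 of 3 stereo elements differ; a stereocentre at a saturated ring carbon is drawn R in compound 3 and S in compound 4. It therefore keeps the chain of compound 3 while sharing the drawn configuration of compound 1 and compound 2.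

Among the measured compounds shown here, no measured pair differs in configuration alone, so the size of this change cannot be read directly. For the measured compounds named here, the only measured step, a 1.9-fold higher number from compound 1 to compound 2 (0.27 log units; within the scatter), concerns the chain and stays within the scatter, so it bears on the change only indirectly. Compound 3 differs from compound 1 and compound 2 in both chain and configuration, and its lower number cannot be divided between the two changes. With the chain unchanged, the value of compound 3, 1990 nM, serves as the anchor, and no step beyond the scatter is expected in this assay. The estimated step is a 1.2-fold higher number from compound 3 to compound 4 (0.08 log units; within the scatter), with wide uncertainty in either direction. For compound 4 the expected value is 2400 nM, within an estimated range from 900 nM to 7000 nM.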

Compound 4, half-maximal inhibitory concentration: 1200 nM
Beside the measured number, compound 4's estimate is 2.0-fold (0.30 log units) above it; the range from low to high includes it.
By their numbers in this assay, from the lowest: compounds 4 and 3 (each within the scatter of the next); then compounds 1 and 2 (each within the scatter of the next).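

In this assay, a 1.7-fold lower number from compound 3 to compound 4 (0.22 log units; within the scatter) gives the first direct reading of this stereocentre at a saturated ring carbon, and it stays within the scatter; the comparison isolates configuration, with the chain held constant: the fact that compounds 3 and 4 differ only in the configuration as drawn

With the drawn configuration shared, the chain can now be read on its own. Two steps lie beyond the scatter, a 19-fold lower number from compound 2 to compound 4 (1.27 log units; beyond the scatter) with heptyl in place of hydrogen and a 9.9-fold lower number from compound 1 to compound 4 (1.00 log units; beyond the scatter) with butyl in place of hydrogen, whereas the shorter step a 1.9-fold higher number from compound 1 to compound 2 (0.27 log units; within the scatter) stayed within it. Among these compounds the clear separation therefore goes with the chain and not with the configuration at this ring carbon.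

Among the compounds shown here, compounds 3 and 4 are the only pair that isolates this stereocentre, so it remains open whether it would matter as little on a heptyl or shorter chain, or how the other stereo elements behave. Also open, on these data alone, is how a longer chain than that of compound 4, or an amide or a carboxylic acid in place of either amine, would read in this assay.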